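The source may hold more compounds than are shown below. What is called first, only, known or untested is meant among the compounds shown, and "the series" means these compounds.

Working notes on the series. Compound 1 `COCC/C(=C(/c1ccc(/C=C/C(=O)O)cc1)c1ccc2[nH]ncc2c1)c1ccccc1` carries a 2-methoxyethyl on the double-bonded chain carbon bound to an aromatic carbon and a double-bonded chain carbon; compound 2 `O=C(O)/C=C/c1ccc(/C(=C(\c2ccccc2)C(F)(F)F)c2ccc3[nH]ncc3c2)cc1` carries a trifluoromethyl at that place. In a functional assay on MCF7 cells (Homo sapiens) for cytotoxicity, read by CellTiter-Glo, with a stated time of 5 days (on this read-out lower numbers stand for stronger inhibition and higher numbers for weaker inhibition), compound 1 gives 63 nM and compound 2 gives 5.5 nM. Going by the values given here, the one measured step, an 11-fold lower number from compound 1 to compound 2 (1.06 log units; beyond the scatter), shows that this position moves the read-out strongly. Compound 2 stands lowest of the two numbers in this assay.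

Compound 3 `O=C(O)/C=C/c1ccc(/C(=C(\c2ccccc2)C2CC2)c2ccc3[nH]ncc3c2)cc1` differs from compound 2 by cyclopropyl in place of trifluoromethyl on a double-bonded chain carbon bound to an aromatic carbon and a double-bonded chain carbon. Among the compounds with values here, no measured step involves a cyclopropyl; the only step that bears on this position is an 11-fold lower number from compound 1 to compound 2 (1.06 log units; beyond the scatter), and it concerns a different exchange, so its size cannot be carried over. The exchange is expected to cost some potency, with an expected step of a 2.7-fold higher number from compound 2 to compound 3 (0.44 log units; beyond the scatter) in this assay. Compound 3 is therefore estimated at 15 nM in this assay, with a range from 4 nM to 60 nM.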

Compound 3, half-maximal inhibitory concentration: 13 nM
Compound 3: middle estimate off by 1.2-fold (0.06 log units), on the high side, and the stated range covers the measured number.
By their numbers in this assay, from the lowest: compound 2; then compound 3; then compound 1.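

In this assay, cyclopropyl on the double-bonded chain carbon bound to an aromatic carbon and a double-bonded chain carbon gives a 2.4-fold higher number from compound 2 to compound 3 (0.37 log units; beyond the scatter), so a group without fluorine nearly holds the level set by trifluoromethyl, though the step remains beyond the scatter. Against the 2-methoxyethyl, the same exchange gives a 4.8-fold lower number from compound 1 to compound 3 (0.69 log units; beyond the scatter), so a low number at this place does not depend on trifluoromethyl alone, and the three groups rank trifluoromethyl, cyclopropyl, 2-methoxyethyl from the lowest number. Nothing at hand accounts for this order.

The three compounds leave open whether the higher number of compound 1 follows from the length of its chain or from its ether oxygen, which a plain butyl chain at this place would separate. Going by these compounds, how a methyl or an ethyl compares with cyclopropyl also remains open.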